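Removing the Fluorine from a Weak Potassium Channel Activator

This account rests on a few compounds, and the source may have more. Where it says the series, first, only, none or still open, it means among the compounds named here.

Measured compounds:
compound 1, `Cc1ccc(NC(=O)CN2CCN(S(=O)(=O)N3CCC(C)CC3)CC2)cc1`, 4100 nM
compound 2, `CC1CCN(S(=O)(=O)N2CCN(CC(=O)Nc3ccccc3F)CC2)CC1`, > 10000 nM

Both compounds share the same core and differ only in the ring carried by the amide-type nitrogen. In an assay on HEK293 cells for activation of potassium channel subfamily T member 1 (Homo sapiens), read by thallium flux (on this read-out higher numbers stand for an effect only at larger amounts of compound and lower numbers for an effect already at smaller amounts), compound 1 gives 4100 nM. For compound 2 the assay reports only a limit, > 10000 nM, not a number. Compound 2 therefore stands at the weak end of what has been measured, sitting at the limit of > 10000 nM in this assay, at which 1 of the 2 values shown sits. Swapping the rings gave an at least 2.4-fold higher number from compound 1 to compound 2 (0.38 log units; beyond the scatter).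

Compound 3, `CC1CCN(S(=O)(=O)N2CCN(CC(=O)Nc3ccccc3)CC2)CC1`, has not been measured in this assay. It differs from compound 2 by hydrogen in place of fluoro on an aromatic carbon. Among the measured compounds shown here, the one measured step exchanged the whole ring at once, so it does not separate the fluoro from the rest of the change, and it offers only a loose guide. With compound 2 at a limit, even a real gain could leave the number beyond what the assay resolves.

Compound 3 is expected to remain weak, at about 9000 nM, within 3000 nM to 30000 nM. This estimate corresponds to an at least 1.1-fold lower number from compound 2 to compound 3 (0.04 log units; that floor lies within the scatter).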

Compound 3, half-maximal effective concentration: > 10000 nM
Compound 3: only a limit was reported; the forecaster's own chance of this, stated with the estimate: 55%; at least 1.1-fold (0.04 log units) between middle value and limit.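

In this assay compound 3 gives > 10000 nM, which is again a limit of the assay and not a number. This compound separates two changes that the earlier ring exchange made at once, because compound 1 and compound 3 differ in a single place: taking the methyl off the ring gave an at least 2.4-fold higher number from compound 1 to compound 3 (0.38 log units; beyond the scatter), so a higher number, meaning that more compound is needed for an effect, appears here with no fluoro on the ring. The step from compound 2 to compound 3 cannot be read, because both compounds rest at a limit and not at a number, so removing the fluoro shows no measurable gain or loss: the limit of > 10000 nM in this assay, at which 2 of the 3 values shown sit.

From the compounds shown here alone, whether the fluoro changes the effect at all remains open, as does how far past the limit compound 2 and compound 3 really lie. Also open, going by these compounds, is whether an ethyl group, a methoxy group or an amine in the place of the methyl of compound 1 would keep its number, raise it or lower it.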